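A Benzyl Swap on the Triazolopyrimidine Core

The compounds below may be only part of what the source reports. "The series", "measured", "known", "first", "only" and "open" are said of these compounds alone.

Compound 1 `CCCSc1nc(N/N=C(\C)c2ccccc2O)c2nnn(Cc3ccco3)c2n1` stands lowest of the two numbers on record in a functional assay on MGC-803 cells (Homo sapiens) for antiproliferative activity, read by MTT assay, with a stated time of 72 h (on this read-out lower numbers stand for stronger inhibition and higher numbers for weaker inhibition), where compound 1 gives 4760 nM. Its nearest neighbour, compound 2 `CCCSc1nc(N/N=C/c2ccccc2Cl)c2nnn(Cc3ccccc3)c2n1`, gives 10900 nM in this assay, a higher number beyond the usual scatter. Compound 3 `CCCSc1nc(N/N=C/c2ccccc2)c2nnn(Cc3ccccc3)c2n1` returns only a limit of this assay, > 64000 nM, rather than a number; this is the limit of > 64000 nM in this assay, at which 1 of the 3 values shown sits. For the measured compounds named here, the one single-point step available, an at least 5.8-fold higher number from compound 2 to compound 3 (0.76 log units; beyond the scatter), concerns the hydrazone-side aryl ring and not the group on the saturated chain carbon bound to the aromatic nitrogen.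

Compound 4 `CCCSc1nc(N/N=C(\C)c2ccccc2O)c2nnn(Cc3ccc(Br)cc3)c2n1` differs from compound 1 by 4-bromophenyl in place of furan-2-yl on a saturated chain carbon bound to an aromatic nitrogen. Going by the values given here, no measured step touches this part of the core, so no movement beyond the scatter can be predicted from the data; compound 1's value remains the anchor. Compound 4 is therefore estimated at 3800 nM, with a range from 1200 nM to 12000 nM. This corresponds to an expected 1.3-fold lower number from compound 1 to compound 4 (0.10 log units; within the scatter).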

Compound 4, half-maximal inhibitory concentration: 11300 nM
For compound 4 the middle estimate is 3.0-fold (0.47 log units) below the measured one, and the stated range covers the measured number.
By their numbers in this assay, from the lowest: compound 1; then compounds 2 and 4 (each within the scatter of the next). At a limit, above all of these: compound 3.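

The step of a 2.4-fold higher number from compound 1 to compound 4 (0.38 log units; beyond the scatter) in this assay gives the group on the saturated chain carbon bound to an aromatic nitrogen a measured movement of its own, where the earlier step touched only the hydrazone-side aryl ring. With the rest of compound 1 held fixed, this position is not indifferent to its group: 4-bromophenyl in place of furan-2-yl weakens inhibition modestly. Nothing measured here bears on the reason for this movement.

The compounds shown do not separate the contribution of the bromine from that of the change of ring, and groups such as 4-chlorophenyl, pyridin-3-yl or cyclohexyl at this place would bear on that. As far as these compounds go, how far a thiophen-2-yl or a longer chain would carry the number in either direction also stays open.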